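The source may report more compounds than this note shows. Statements on the series, on what has been measured and on what is new or still open speak of the compounds shown alone.

Three sulfonamide-bearing compounds were examined in an assay on HEK293 cells for displacement of a labelled ligand from 5-hydroxytryptamine receptor 7 (Homo sapiens), read by scintillation counting, with a stated time of 1 h; a lower number here means a stronger inhibitor, a higher number a weaker inhibitor. Compound 1 `CC(COc1ccccc1-c1ccccc1)N1CCC(NS(=O)(=O)c2cccc(Cl)c2)CC1` gives 32 nM in this assay, and compound 2 `CC(COc1ccccc1-c1ccccc1)N1CCC(NS(=O)(=O)c2ccc(F)cc2)CC1` gives 34 nM. Compound 2 differs from compound 1 in one place: 4-fluorophenyl in place of 3-chlorophenyl on a sulfonyl sulfur. In this assay that change gave a 1.1-fold higher number from compound 1 to compound 2 (0.03 log units; within the scatter).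

Compound 3 `O=S(=O)(NC1CCN(CCCOc2ccccc2-c2ccccc2)CC1)c1cccc(Cl)c1` is built from the same atoms as compound 1, joined differently; the difference between the two cores is not broken down here. In this assay compound 3 gives 52 nM, which lies within the scatter of the numbers for compound 1 and compound 2.

Compound 4 `O=S(=O)(NC1CCN(CCCOc2ccccc2-c2ccccc2)CC1)c1ccc(F)cc1` has not yet been measured. It stands to compound 3 exactly as compound 2 stands to compound 1, since the change is the same: 4-fluorophenyl in place of 3-chlorophenyl on a sulfonyl sulfur.

The step expected from compound 3 to compound 4 in this assay is a 1.1-fold higher number from compound 3 to compound 4 (0.02 log units; within the scatter), because the same change gave a 1.1-fold higher number from compound 1 to compound 2 (0.03 log units; within the scatter) on the other core. Compound 4 is therefore estimated at about 55 nM in this assay, with the expected range running from 25 nM to 120 nM.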

Compound 4, inhibition constant: 58 nM
Beside the measured number, compound 4's estimate is 1.1-fold (0.02 log units) below it; low and high end bracket the measured number.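

In this assay, putting 4-fluorophenyl in place of 3-chlorophenyl on the sulfonyl sulfur of compound 3 gave a 1.1-fold higher number from compound 3 to compound 4 (0.05 log units; within the scatter). Set beside the earlier step, the change carries from the core of compound 1 to the core of compound 3 with no difference beyond the scatter: the same change on two cores in this assay, a 1.1-fold higher number (0.03 log units; within the scatter) from compound 1 to compound 2 and a 1.1-fold higher number (0.05 log units; within the scatter) from compound 3 to compound 4, 1.0-fold (0.02 log units) apart, within the scatter of two such steps. This shows that the swap leaves the number within the scatter on both cores, but it does not show that the same would hold on any further core or in another assay, and since neither step rises above the scatter, it cannot show whether a step of real size would carry over in the same way.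

On these data alone, only 3-chlorophenyl and 4-fluorophenyl appear on the sulfonyl sulfur here, so it remains open what an amine, a carboxylic acid or a methoxy group on that aromatic ring would do. Also open, as far as these compounds go, is whether a longer chain than those of compound 1 and compound 3 would give the same picture in this assay.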